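Swapping the acid-derived ring on a thiophene amide core

The source may report more compounds than this note shows. Statements on the series, on what has been measured and on what is new or still open speak of the compounds shown alone.

Compound 1 `CC1(C)Cc2c(sc(NC(=O)c3cccnc3O)c2C(N)=O)C(C)(C)O1` is one of two molecules sharing the same core and tested in an assay on cells for positive allosteric modulation of Cystic fibrosis transmembrane conductance regulator variant F508del (Homo sapiens), with stated times of 10 min and 7 s, in the presence of a further agent that is not named here; on this read-out higher numbers stand for an effect only at larger amounts of compound and lower numbers for an effect already at smaller amounts. In this assay compound 1 gives 190 nM, the highest of the two numbers, while compound 2 `CC1(C)Cc2c(sc(NC(=O)c3cn[nH]c3)c2C(N)=O)C(C)(C)O1` gives 125 nM. Within the data shown here, the only measured step that changes this part of the molecule, a 1.5-fold lower number from compound 1 to compound 2 (0.18 log units; within the scatter), shows that exchanging the ring attached to the carbonyl carbon left the read-out essentially unchanged.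

Compound 3 `CC1(C)Cc2c(sc(NC(=O)c3cc(C(F)(F)F)n[nH]3)c2C(N)=O)C(C)(C)O1` has not yet been measured. It differs from compound 1 as follows: 3-(trifluoromethyl)-1H-pyrazol-5-yl in place of 2-hydroxypyridin-3-yl on a carbonyl carbon. The change again replaces the ring on the carbonyl carbon with a pyrazole, now carrying a trifluoromethyl group. Since the comparable step to compound 2 stayed within the scatter, no step beyond the scatter is expected for compound 3 either, a 1.2-fold lower number from compound 1 to compound 3 (0.07 log units; within the scatter). Compound 3 is therefore estimated at 160 nM, with a plausible range from 50 nM to 500 nM.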

Compound 3, half-maximal effective concentration: 3 nM
The estimate for compound 3 lay 53-fold (1.73 log units) above the measured number; the measured number lies below the stated range.
By their numbers in this assay, from the lowest: compound 3; then compounds 2 and 1 (each within the scatter of the next).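

In this assay, the ring on the carbonyl carbon proves able to shift the read-out strongly: a 63-fold lower number from compound 1 to compound 3 (1.80 log units; beyond the scatter), and a 42-fold lower number from compound 2 to compound 3 (1.62 log units; beyond the scatter), whereas the earlier ring exchange stayed within the scatter. Compound 2 and compound 3 both carry a pyrazole, so a pyrazole ring alone does not go with the low number; 3-(trifluoromethyl)-1H-pyrazol-5-yl does, at least on this shared core. The data shown offer no measurement that explains the size of this step.

As far as these compounds go, compound 3 differs from compound 2 both in the trifluoromethyl group and in how the pyrazole is attached, so the share of each in the step remains open. A 1H-pyrazol-5-yl ring with no substituent, or with a methyl group or a nitrile in place of trifluoromethyl, would help separate the two.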